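The compounds below may be only part of what the source reports. "The series", "measured", "known", "first", "only" and "open" are said of these compounds alone.

Of the compounds shown here, three have so far been measured in an assay on HEK293 cells for positive allosteric modulation of metabotropic glutamate receptor 2 (Rattus norvegicus), read by thallium flux, with a stated time of 2.5 min (a higher number here means that more compound is needed for the effect, a lower number that less compound is needed), and a fourth awaits its number.

Compound 1 `CCCC(=O)c1ccc(OCCCCOc2cc(C(=O)O)ccc2OC)c(C)c1O` gives 103 nM in this assay. Compound 2 `COc1ccc(C(=O)O)cc1OCCCCOc1ccc(C(=O)CC(C)C)c(O)c1C` differs from compound 1 in one place, (methyl in place of hydrogen on a saturated chain carbon bound to two saturated chain carbons). In this assay compound 2 gives 155 nM; the step is a 1.5-fold higher number from compound 1 to compound 2 (0.18 log units; within the scatter). Compound 3 `CCC(=O)c1ccc(OCCCCOc2ccc(F)c(C(=O)O)c2)c(C)c1O` gives 124 nM. The difference between the core of compound 3 and the core of compound 1 is not broken down here, and the two values lie within the scatter of each other, as do those of compounds 3 and 2.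

Compound 4 `Cc1c(OCCCCOc2ccc(F)c(C(=O)O)c2)ccc(C(=O)C(C)C)c1O` has not yet been measured in this assay. It differs from compound 3 as methyl in place of hydrogen on a saturated chain carbon bound to a carbonyl carbon and a saturated chain carbon. This is the same kind of change as that from compound 1 to compound 2, but not the same: there the methyl enters on a saturated chain carbon bound to two saturated chain carbons, here on a saturated chain carbon bound to a carbonyl carbon and a saturated chain carbon.

Going by the values given here, the one precedent, a 1.5-fold higher number from compound 1 to compound 2 (0.18 log units; within the scatter), lay within the scatter, so the expected step is a 1.3-fold higher number from compound 3 to compound 4 (0.12 log units; within the scatter), resting on the value of compound 3, 124 nM. For compound 4 the estimate in this assay is 165 nM, with 80 nM to 340 nM as the expected range.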

Compound 4, half-maximal effective concentration: 171 nM
The estimate for compound 4 lay 1.0-fold (0.02 log units) below the measured number, within the range that was stated.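

In this assay the new step is a 1.4-fold higher number from compound 3 to compound 4 (0.14 log units; within the scatter). Set beside the earlier step, the extra methyl gives matching results on the two cores, so in these two pairs the change carries over without a detectable difference: the same change on two cores in this assay, a 1.5-fold higher number (0.18 log units; within the scatter) from compound 1 to compound 2 and a 1.4-fold higher number (0.14 log units; within the scatter) from compound 3 to compound 4, 1.1-fold (0.04 log units) apart, within the scatter of two such steps

This does not show that the methyl changes the number at all, since each step lies within the scatter, and two pairs give no rule for other cores. The two changes are also not identical: in one the methyl enters on a saturated chain carbon bound to two saturated chain carbons, in the other on a saturated chain carbon bound to a carbonyl carbon and a saturated chain carbon.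

Going by these compounds, whether a longer chain or a cyclopropyl in place of the isopropyl of compound 4 would give a step beyond the scatter stays open. So does whether the same methyl step would hold on a core carrying an amide in place of the carboxylic acid.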